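Chloro for Fluoro at the Edge of the Scatter

The compounds below may be only part of what the source reports. "The series", "measured", "known", "first", "only" and "open" are said of these compounds alone.

Three measured compounds share one core and differ only in the group attached to it. Compound 1 `Nc1ncnn2c([C@@H]3O[C@H](CO)[C@@H](O)[C@H]3O)cc(C#Cc3ccc(F)cc3)c12` gives 55400 nM in a functional assay on CAPAN-1 cells (Homo sapiens) for antiproliferative activity, with a stated time of 72 h; on this read-out lower numbers stand for stronger inhibition and higher numbers for weaker inhibition. Compound 2 `Nc1ncnn2c([C@@H]3O[C@H](CO)[C@@H](O)[C@H]3O)cc(C#Cc3ccccc3)c12` gives 37700 nM in this assay, and compound 3 `Nc1ncnn2c([C@@H]3O[C@H](CO)[C@@H](O)[C@H]3O)cc(-c3ccc(F)cc3)c12` gives 65600 nM. Compound 3 stands highest of the three numbers, yet each step leading to it is within the scatter: a 1.2-fold higher number from compound 1 to compound 3 (0.07 log units; within the scatter) and a 1.7-fold higher number from compound 2 to compound 3 (0.24 log units; within the scatter). The remaining step, a 1.5-fold lower number from compound 1 to compound 2 (0.17 log units; within the scatter), shows the same picture, so nothing among these three rises above noise.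

Compound 4 `Nc1ncnn2c([C@@H]3O[C@H](CO)[C@@H](O)[C@H]3O)cc(-c3ccc(Cl)cc3)c12` differs from compound 3 by a single atom: chloro in place of fluoro on an aromatic carbon. Among the compounds with values here, no measured step swaps one halogen for another; the nearest guide is the step from compound 1 to compound 2, where removing the fluoro moved the number only within the scatter. Since every change so far has left the read-out roughly where it was, the step of a 1.2-fold lower number from compound 3 to compound 4 (0.08 log units; within the scatter) is expected to stay within the scatter as well. Compound 4 is therefore estimated at 55000 nM in this assay, with a range from 20000 nM to 150000 nM.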

Compound 4, half-maximal inhibitory concentration: 56700 nM
The estimate for compound 4 lay 1.0-fold (0.01 log units) below the measured number; the measured number falls inside the stated range.
By their numbers in this assay, from the lowest: compounds 2, 1, 4 and 3 (each within the scatter of the next).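

Within the data shown here, this is the first direct exchange of one halogen for another on an aromatic carbon para to a large group, and in this assay it leaves chloro and fluoro indistinguishable (a 1.2-fold lower number from compound 3 to compound 4 (0.06 log units; within the scatter)). Among these compounds, the 4-chlorophenyl group also cannot be told apart from either ethynyl-linked group (a 1.0-fold higher number from compound 1 to compound 4 (0.01 log units; within the scatter); a 1.5-fold higher number from compound 2 to compound 4 (0.18 log units; within the scatter)), so the new compound joins the earlier three with no step rising above the scatter. No supporting data are available to explain why these changes leave the read-out so little altered.

As far as these compounds go, it remains open whether an amine or a carboxylic acid on this phenyl ring would move the number beyond the scatter. Also open, from the compounds shown here alone, is whether a 2-(4-chlorophenyl)ethynyl group would read the same as its fluoro counterpart.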